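The source may hold more compounds than are shown below. What is called first, only, known or untested is meant among the compounds shown, and "the series" means these compounds.

The account concerns compound 1 `Nc1nc2c(c(-c3ccccc3)cn2[C@@H]2O[C@H](CO)[C@@H](O)[C@H]2O)c(=O)[nH]1` and a compound derived from it, compound 4 `Nc1nc2c(c(-c3cc4ccccc4o3)cn2[C@@H]2O[C@H](CO)[C@@H](O)[C@H]2O)c(=O)[nH]1`. In an ADME assay on BJ cells (Homo sapiens), read by MTT assay, with a stated time of 72 h (on this read-out lower numbers stand for stronger inhibition and higher numbers for weaker inhibition), compound 1 gives > 100000 nM, which is a limit of the assay and not a number. Where compound 1 stands among the numbers shown is therefore only partly known: it sits at the limit of > 100000 nM in this assay, at which 1 of the 3 values shown sits. Two other compounds, built on other cores, do give numbers. In this assay compound 2 `COc1ncnc2c1c(-c1cc3ccccc3o1)cn2[C@@H]1O[C@H](CO)[C@@H](O)[C@H]1O` gives 22400 nM. In this assay compound 3 `C#Cc1cn([C@@H]2O[C@H](CO)[C@@H](O)[C@H]2O)c2ncnc(NC)c12` gives 86000 nM. The change from compound 1 to compound 4 is 1-benzofuran-2-yl in place of phenyl on an aromatic carbon. No step between two measured compounds of this set is shown, so the size of this change in this assay is not known from any measured pair. Compound 2 carries the same 1-benzofuran-2-yl group and gives a number rather than a limit, but its core differs from that of compound 1 in more than one place, so only its value is known, not a step. Compound 4 is expected to give a number rather than a limit, with a step from compound 1 that is expected to be an at least 2.0-fold lower number from compound 1 to compound 4 (0.30 log units; that floor lies within the scatter) toward stronger inhibition. The estimate for compound 4 is 50000 nM, within 15000 nM to 200000 nM.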

Compound 4, half-maximal inhibitory concentration: > 100000 nM
Compound 4: a limit, no number; the forecaster's own chance of this, stated with the estimate: 40%; middle value at least 2.0-fold (0.30 log units) away from the limit.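

In this assay compound 4, like compound 1, gives a limit of the assay and not a number, so no step can be read between these two compounds: the limit of > 100000 nM in this assay, at which 2 of the 4 values shown sit.

The compounds shown leave open whether 1-benzofuran-2-yl in place of phenyl on the core of compound 1 changes the value in this assay at all, and by how much.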